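The source may hold more compounds than are shown below. What is called first, only, known or untested is meant among the compounds shown, and "the series" means these compounds.

The three measured compounds share one core and differ in the group carried on an aromatic carbon. Compound 1 `CCCCc1[nH]c(=O)c(-c2nc(Cc3ccccc3)no2)c(O)c1-c1c(OC)cccc1OC` gives 69% in an ADME assay on microsomes from liver (Homo sapiens) for metabolic stability, read by mass spectrometry, using NADPH, with a stated time of 10 min; on this read-out higher numbers stand for a more stable compound and lower numbers for a less stable compound. Compound 2 `CCCCc1[nH]c(=O)c(-c2nnc(Cc3ccc(Cl)cc3)o2)c(O)c1-c1c(OC)cccc1OC` gives 66% in this assay. Compound 3 `COc1cccc(OC)c1-c1c(C2CCCC2)[nH]c(=O)c(-c2nnc(Cc3ccc(Cl)cc3)o2)c1O` gives 80% in this assay, the highest of the three numbers; its gap to compound 1 and its gap to compound 2 both lie beyond the scatter. The only single-point step among these three is a number 14 percentage points higher from compound 2 to compound 3 (beyond the scatter), a modest rise.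

Compound 4 `COCCc1[nH]c(=O)c(-c2nnc(Cc3ccc(Cl)cc3)o2)c(O)c1-c1c(OC)cccc1OC` has not yet been measured. It differs from compound 3 in one place: 2-methoxyethyl in place of cyclopentyl on an aromatic carbon. For the measured compounds named here, the one measured step that touches this site, a number 14 percentage points higher from compound 2 to compound 3 (beyond the scatter), went upward when the cyclopentyl took the place of the butyl. Going by the values given here, no measured pair carries a 2-methoxyethyl, so the direction for compound 4 rests on that single step and on the fact that the cyclopentyl is lost. Because a number 14 percentage points higher from compound 2 to compound 3 (beyond the scatter) rose on gaining the cyclopentyl, losing it is expected to give back part of that gain. Compound 4 is therefore expected to show a downward step of a number 12 percentage points lower from compound 3 to compound 4 (beyond the scatter) in this assay. The estimate for compound 4 in this assay is 68%, with a range from 52% to 84%.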

Compound 4, percent of the compound remaining: 86%
Estimate against measurement, compound 4: 18 percentage points below; the measured number lies above the stated range.
By their numbers in this assay, from the lowest: compounds 2 and 1 (each within the scatter of the next); then compounds 3 and 4 (each within the scatter of the next).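

In this assay, the position next to the ring nitrogen accepts an open chain as well as a ring: the 2-methoxyethyl and the cyclopentyl cannot be told apart, with a number 6 percentage points higher from compound 3 to compound 4 (within the scatter). Set against the butyl, the same position shows a number 20 percentage points higher from compound 2 to compound 4 (beyond the scatter), a step that swaps an ethyl for a methoxy on the saturated chain, so the earlier rise from the butyl is no longer seen with the cyclopentyl alone, and a ring at this position is not required for it. Nothing measured here accounts for either step, and the reason for these numbers remains unknown.

The compounds shown leave open whether the oxygen in the chain matters in itself, since a chain ending in a hydroxy group, a 3-methoxypropyl chain or a chain ending in a dimethylamine would each test this position further. For the compounds shown here, they also leave open whether the 2-methoxyethyl would act in the same way on the core of compound 1, where the butyl is the only group seen at this position.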